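Phenyl Replaces Carboxy-Chlorophenyl in a Liver-Microsome Stability Series

The source may hold more compounds than are shown below. What is called first, only, known or untested is meant among the compounds shown, and "the series" means these compounds.

Measured so far:
compound 1 `O=C(O)c1ccc(-c2cccc(COc3ccc4c(c3)CN(C3CCCC3)C4=O)c2)c(Cl)c1` — 3%
compound 2 `CC(C)Cn1sc2cc(OCc3cccc(-c4ccc(Cl)c(C(=O)O)c4)c3)ccc2c1=O` — 86%
compound 3 `O=C(O)c1cc(-c2cccc(COc3ccc4c(=O)n(C5CCCC5)sc4c3)c2)ccc1F` — 71%

Of the compounds shown here, three have been tested in an ADME assay on microsomes from liver (Rattus norvegicus) for metabolic stability, read by LC-MS, with a stated time of 1 h, at 37 degrees C, tested at 4 uM; a lower number here means that less of the compound is left, a higher number that more of the compound is left. Compound 1 gives 3%, the lowest of the three numbers. Its nearest neighbour is compound 3, which gives 71%, and the gap between them lies beyond the scatter. Compound 2 stands furthest away with 86%, again a difference beyond the scatter. Among the measured compounds shown here, no steps between measured compounds that differ in a single place are available, so nothing can yet be said about what one change does.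

The next compound, compound 4 `O=C1c2ccc(OCc3cccc(-c4ccccc4)c3)cc2CN1C1CCCC1`, is derived from compound 1 by one change: phenyl in place of 4-carboxy-2-chlorophenyl on an aromatic carbon. For the measured compounds named here, since compound 1 is already near the bottom of the scale in this assay, there is little room for the number to fall further, and no measured step tells how far it might rise. The step from compound 1 to compound 4 is therefore expected to be small, within the scatter or at most modestly upward, giving a number 5 percentage points higher from compound 1 to compound 4 (within the scatter). Compound 4 is estimated to give 8% in this assay, with a range from 0% to 30%.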

Compound 4, percent of the compound remaining: 38%
For compound 4 the middle estimate is 30 percentage points below the measured one; the measured number lies above the stated range.
By their numbers in this assay, from the lowest: compound 1; then compound 4; then compound 3; then compound 2.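

Among the compounds shown here, this is the first step that differs in a single place, and it shows that the group at this position matters. In this assay, phenyl in place of 4-carboxy-2-chlorophenyl on an aromatic carbon gives a number 35 percentage points higher from compound 1 to compound 4 (beyond the scatter), so a large shift comes from this one change while the rest of the molecule stays the same. The change removes the carboxy group and the chlorine together, so the step cannot be assigned to either one, and nothing measured here explains it.

On these data alone, it remains open whether a phenyl carrying only a chlorine, or only a carboxylic acid, would sit nearer compound 1 or compound 4. As far as these compounds go, it is also open whether the same replacement would move compound 2 or compound 3 in the same direction.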